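The source may hold more compounds than are shown below. What is called first, only, known or untested is meant among the compounds shown, and "the series" means these compounds.

Compound 1 `CCc1oc2c(C)c(OCc3cccc(C(F)(F)F)c3)ccc2c(=O)c1Br` and compound 2 `CCc1cc(=O)c2ccc(OC)c(CBr)c2o1` were tested in a functional assay on DU-145 cells (Homo sapiens) for antiproliferative activity, read by sulforhodamine B assay, with a stated time of 72 h; a lower number here means a stronger inhibitor of growth, a higher number a weaker inhibitor of growth. For compound 1 only a limit of the assay is recorded, > 22600 nM. For compound 2 likewise only a limit is recorded, > 33600 nM. Compound 2 therefore stands at a limit rather than at a number, as does the other value shown (the limit of > 22600 nM in this assay, at which 1 of the 2 values shown sits). Compound 3 `CCc1cc(=O)c2ccc(OC(C)C)c(CBr)c2o1` differs from compound 2 by isopropyl in place of methyl on an oxygen on an aromatic ring. For the measured compounds named here, no step between measured compounds is available, so in this assay a step from compound 2 to compound 3 of about a step that the limit leaves unreadable from compound 2 to compound 3 is expected, none beyond the scatter. Compound 3 is estimated at 35000 nM, within 10000 nM to 120000 nM.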

Compound 3, concentration for 50% growth inhibition: > 30700 nM
Compound 3: only a limit was reported; the forecaster's own chance of this, stated with the estimate: 75%; the middle value is on the limit's open side.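

No step can be read between compound 2 and compound 3 in this assay; both values are limits. The compounds shown leave open whether methoxy to isopropoxy alters growth inhibition, and at what concentration any of them inhibits growth.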